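Methyl to Fluoro on Two Related Dichloroacetamides

A few compounds are considered here, and "the series" means these few. Any claim that something is new, unique, unknown or untested is made for them only; others in the source may bear on it.

Compound 1 `Cc1ccccc1-c1cccc(NC(=O)C(Cl)Cl)c1` and compound 2 `O=C(Nc1cccc(-c2ccccc2F)c1)C(Cl)Cl` share one core and differ in a single spot. In a functional assay on KB 3-1 cells (Homo sapiens) for cytotoxicity, read by MTT assay, with a stated time of 68 h (on this read-out lower numbers stand for stronger inhibition and higher numbers for weaker inhibition), compound 1 gives 42000 nM. In this assay compound 2 gives 48300 nM. The change between them is fluoro in place of methyl on an aromatic carbon, and it made a 1.2-fold higher number from compound 1 to compound 2 (0.06 log units; within the scatter).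

Compound 3 `Cc1ccc(-c2cccc(NC(=O)C(Cl)Cl)c2)cc1` has the same atoms as compound 1, joined differently; the difference between the two cores is not broken down here. In this assay compound 3 reaches only a limit of the assay, > 50000 nM, so no number is known for it. Compound 4 `O=C(Nc1cccc(-c2ccc(F)cc2)c1)C(Cl)Cl` has not been measured yet. Its difference from compound 3 is fluoro in place of methyl on an aromatic carbon. Within the data shown here, this is the same kind of change as the one between compound 1 and compound 2, but not the same: in the measured pair the fluoro sits ortho to a large group, while in the new pair it sits para to a large group.

The expectation for compound 4 rests on two things: on a 1.2-fold higher number from compound 1 to compound 2 (0.06 log units; within the scatter), and on the fact that compound 3 sits at the limit of > 50000 nM in this assay, at which 1 of the 3 values shown sits. Since the measured pair moved so little, the new pair is expected to move little as well. The step from compound 3 to compound 4 is estimated as a step that the limit leaves unreadable from compound 3 to compound 4. Compound 4 is therefore expected to give about 60000 nM, with the estimate lying between 25000 nM and 150000 nM, and a real chance that only a limit is reported again.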

Compound 4, half-maximal inhibitory concentration: 26200 nM
Beside the measured number, compound 4's estimate is 2.3-fold (0.36 log units) above it, and the stated range covers the measured number.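

Compound 3 in this assay gives > 50000 nM, which is a limit of the assay and not a number. Carried onto the core of compound 3, fluoro in place of methyl gives an at least 1.9-fold lower number from compound 3 to compound 4 (0.28 log units; that floor lies within the scatter), so the true step may be larger than this floor, but the data do not show that it is. The result therefore neither confirms nor rules out that this change behaves alike on the two cores, and the comparison stays undecided: the same change on two cores in this assay, a 1.2-fold higher number (0.06 log units; within the scatter) from compound 1 to compound 2 and an at least 1.9-fold lower number (0.28 log units; that floor lies within the scatter) from compound 3 to compound 4; the limit leaves it open whether they differ

The compounds shown carry only methyl or fluoro on that aromatic ring, so it remains open how a chloro group, a methoxy group or an amine in the same place would compare. Also open, as far as these compounds go, is the real size of the step to compound 4, since only a limit stands for compound 3, and whether any of these changes would move the numbers far in this assay.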